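A few compounds are considered here, and "the series" means these few. Any claim that something is new, unique, unknown or untested is made for them only; others in the source may bear on it.

The measured compounds:

compound 1, `O=C(O)c1ccccc1-c1ccc(CCc2ncc(CC3CCCCC3)[nH]2)cc1`: 41 nM
compound 2, `N#Cc1ccccc1Cc1cnc(CCc2ccc(-c3ccccc3C(=O)O)cc2)[nH]1`: 5480 nM
compound 3, `O=C(O)c1ccccc1-c1ccc(CCc2ncc(Cc3cccc(F)c3F)[nH]2)cc1`: 87 nM

All three numbers come from an in vitro functional assay on cells for agonist activity at Bombesin receptor subtype-3 (Homo sapiens), read by luminescence and calcium flux; on this read-out lower numbers stand for an effect already at smaller amounts and higher numbers for an effect only at larger amounts of compound. Compound 3 stands second highest of the three; the nearest step to it is a 2.1-fold higher number from compound 1 to compound 3 (0.33 log units; beyond the scatter) and the furthest is a 63-fold lower number from compound 2 to compound 3 (1.80 log units; beyond the scatter). Compound 4 is `O=C(O)c1ccccc1-c1ccc(CCc2ncc(Cc3ccc(Cl)cc3)[nH]2)cc1`, and it differs from compound 3 by 4-chlorophenyl in place of 2,3-difluorophenyl on a saturated chain carbon bound to an aromatic carbon.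

Going by the values given here, the steps that bear on this change are those that swap the group on a saturated chain carbon bound to an aromatic carbon: a 130-fold higher number from compound 1 to compound 2 (2.13 log units; beyond the scatter), a large step, beside the two already named, one modest and one large. They show that this place can move the number a great deal, yet the two aromatic groups measured so far sit at opposite ends, and no 4-chlorophenyl has been measured in this set, so the direction is uncertain. Compound 4 is therefore expected to show a 1.5-fold lower number from compound 3 to compound 4 (0.16 log units; within the scatter), a change within the scatter. The estimate for compound 4 is 60 nM, with a range from 15 nM to 400 nM.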

Compound 4, half-maximal effective concentration: 2290 nM
For compound 4 the middle estimate is 38-fold (1.58 log units) below the measured one; measured number above the stated range.
By their numbers in this assay, from the lowest: compound 1; then compound 3; then compound 4; then compound 2.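

Among the groups on a saturated chain carbon bound to an aromatic carbon, a halogen-bearing phenyl ring does not by itself keep the number low: 4-chlorophenyl in place of 2,3-difluorophenyl gives a 26-fold higher number from compound 3 to compound 4 (1.42 log units; beyond the scatter). The same group stays well away from the cyclohexyl compound, with a 56-fold higher number from compound 1 to compound 4 (1.75 log units; beyond the scatter), and lands much nearer the 2-cyanophenyl compound, with a 2.4-fold lower number from compound 2 to compound 4 (0.38 log units; beyond the scatter), so that of the three aromatic groups only the 2,3-difluorophenyl of compound 3 stays close to cyclohexyl. Nothing available explains why these groups differ so widely.

Going by these compounds, how 4-fluorophenyl or 2,3-dichlorophenyl would stand at this place remains open, and with it whether the number follows the halogen or its place on the ring. Also open, on these data alone, is how unsubstituted phenyl would compare with cyclohexyl here.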